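Shortening the Hydroxamic Acid Chain on Compound 1

This account rests on a few compounds, and the source may have more. Where it says the series, first, only, none or still open, it means among the compounds named here.

Going by the values given here, compound 1, with the structure `CCOc1cc(C(C)(C)C)ccc1C1=NC(c2ccc(Cl)cc2)C(c2ccc(Cl)cc2)N1C(=O)N1CCN(CCCCCC(=O)NO)CC1`, is the one compound here with a measured number: in a functional assay on MCF7 cells (Homo sapiens) for antiproliferative activity, read by CCK-8 assay, with a stated time of 72 h (on this read-out higher numbers stand for weaker inhibition and lower numbers for stronger inhibition), compound 1 gives 7260 nM. Compound 2, with the structure `CCOc1cc(C(C)(C)C)ccc1C1=NC(c2ccc(Cl)cc2)C(c2ccc(Cl)cc2)N1C(=O)NCCCCCCC(=O)Nc1ccccc1N`, gives only a limit of the assay in this assay, namely > 100000 nM; as the limit of > 100000 nM in this assay, at which 1 of the 2 values shown sits, shows, one of the two values stands at that limit rather than being a number.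

Compound 3, with the structure `CCOc1cc(C(C)(C)C)ccc1C1=NC(c2ccc(Cl)cc2)C(c2ccc(Cl)cc2)N1C(=O)N1CCN(CCCCC(=O)NO)CC1`, keeps the shared core and differs from compound 1 in one place: hydroxycarbamoyl in place of (hydroxycarbamoyl)methyl on a saturated chain carbon, four bonds along the chain from an amine nitrogen in a ring. Among the compounds with values here, since no step between measured compounds is at hand, the effect of trimming the chain by this much is expected to stay close to the scatter, perhaps a modest weakening. Compound 3 is therefore estimated at 9000 nM, with a range from 3000 nM to 30000 nM, which means an expected step of a 1.2-fold higher number from compound 1 to compound 3 (0.09 log units; within the scatter).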

Compound 3, half-maximal inhibitory concentration: 9800 nM
The estimate for compound 3 lay 1.1-fold (0.04 log units) below the measured number, and the stated range covers the measured number.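

Trimming the chain, with hydroxycarbamoyl in place of (hydroxycarbamoyl)methyl, gives in this assay a 1.3-fold higher number from compound 1 to compound 3 (0.13 log units; within the scatter). Going by these compounds alone, this is the first step that can be read at this position, and it shows that the two chain lengths in compound 1 and compound 3 cannot be told apart in this read-out. Nothing in the data shown bears on why this step is so small.

On these data alone, it remains open whether a still shorter chain, such as 2-(hydroxycarbamoyl)ethyl, or a longer chain would give a step beyond the scatter. As far as these compounds go, it is equally open whether the hydroxycarbamoyl group itself matters at this position, which a carboxylic acid or a primary amide in its place on the same chain could test.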